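The compounds below may be only part of what the source reports. "The series", "measured", "known", "first", "only" and "open" are said of these compounds alone.

Measured compounds and their values:
- Compound 1 `O=C(C1CC=CC1)N1CC2CC(C1)N2`: 51 nM
- Compound 2 `O=C([C@H]1C[C@H]1F)N1CC2CC(C1)N2`: 1.1 nM
- Compound 3 `O=C([C@@H]1C[C@@H]1F)N1CC2CC(C1)N2`: 1.7 nM

In an assay on SH-EP1 cells for displacement of a labelled ligand from Neuronal acetylcholine receptor; alpha4/beta2 (Homo sapiens), read by scintillation counting (on this read-out lower numbers stand for stronger inhibition and higher numbers for weaker inhibition), compound 3 gives 1.7 nM, the second highest of the three numbers. Its nearest neighbour is compound 2, which in this assay gives 1.1 nM; the step of a 1.5-fold higher number from compound 2 to compound 3 (0.19 log units; within the scatter) lies within the scatter, and the only difference between the two is the drawing of their stereocentres, as noted in the fact that one of compounds 2 and 3 is drawn with a defined configuration and the other without, at the place where they differ. Compound 1, with 51 nM, sits far higher than compound 3, a gap beyond the scatter.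

Compound 4 `C[C@@H]1C[C@H]1C(=O)N1CC2CC(C1)N2` has not been measured. It differs from compound 3 in one place: 2-methylcyclopropyl in place of 2-fluorocyclopropyl on a carbonyl carbon. Going by the values given here, none of the measured steps covers such a change; the single measured step, from compound 2 to compound 3, concerns stereochemistry alone and was within the scatter. The expectation therefore rests on little: compound 4 is expected to give a somewhat higher number than compound 3, a step of a 2.9-fold higher number from compound 3 to compound 4 (0.47 log units; beyond the scatter), with wide uncertainty. The estimate for compound 4 is 5 nM, between 1.5 nM and 20 nM.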

Compound 4, inhibition constant: 1 nM
Compound 4: middle estimate off by 5.0-fold (0.70 log units), on the high side; measured number outside the range, below it.
By their numbers in this assay, from the lowest: compounds 4, 2 and 3 (each within the scatter of the next); then compound 1.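

In this assay, the exchange of 2-fluorocyclopropyl for 2-methylcyclopropyl on a carbonyl carbon gives a 1.7-fold lower number from compound 3 to compound 4 (0.23 log units; within the scatter) and a 1.1-fold lower number from compound 2 to compound 4 (0.04 log units; within the scatter), so this change cannot be told apart from repeated measurement. Among these compounds, then, the fluorine is not required for a number of this size, which the earlier compounds, all with fluorine or with the unrelated ring of compound 1, could not show. No available observation bears on this exchange.

As far as these compounds go, it remains open whether 2-methylcyclopropyl drawn with the opposite configuration would also match compound 4, as compounds 2 and 3 match each other. From the compounds shown here alone, it is also open whether a cyclopropyl ring carrying an amine, a carboxylic acid or a longer chain such as propyl would hold the number at this place.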